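The compounds below may be only part of what the source reports. "The series", "measured", "known", "first", "only" and "open" are said of these compounds alone.

Measured so far in an assay on FRT cells with Cystic fibrosis transmembrane conductance regulator variant F508del (Homo sapiens) as the target, read by fluorescence, with a stated time of 25 min; on this read-out lower numbers stand for smaller maximal responses and higher numbers for larger maximal responses:
Compound 1 `NC(=O)C1CCN(c2nc(-c3ccccn3)nc3c2CN(Cc2ccccc2)CC3)CC1` gives 56.6%.
Compound 2 `NC(=O)CN1CCN(c2nc(-c3ccccn3)nc3c2CN(Cc2ccccc2)CC3)CC1` gives 57.9%.
Compound 3 `CN(C)CCN1CCN(c2nc(-c3ccccn3)nc3c2CN(Cc2ccccc2)CC3)CC1` gives 41.3%.

Compound 3 stands lowest of the three: the step of a number 15.3 percentage points lower from compound 1 to compound 3 (beyond the scatter) and the step of a number 16.6 percentage points lower from compound 2 to compound 3 (beyond the scatter) both go beyond the scatter, while a number 1.3 percentage points higher from compound 1 to compound 2 (within the scatter) does not. Compound 4 `CN(C)CCN1CCN(c2nc(-c3ccccn3)nc3c2CN(S(=O)(=O)c2ccccc2)CC3)CC1` differs from compound 3 in one place: phenylsulfonyl in place of benzyl on an amine nitrogen in a ring. For the measured compounds named here, none of the three measured steps touches this position; all of them alter the other ring substituent, so no measured step bears directly on the change. In the absence of such a comparison the expected step in this assay is none beyond the scatter, a number 0.3 percentage points lower from compound 3 to compound 4 (within the scatter). Compound 4 is therefore estimated at 41%, with a range from 29% to 55%.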

Compound 4, largest response reached (Emax), in percent of the reference or control that the assay uses: "not active" (no number reported)
Nothing numeric was reported for compound 4, so the estimate cannot be set against anything.
By their numbers in this assay, from the lowest: compound 3; then compounds 1 and 2 (each within the scatter of the next).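

For the compounds shown here, compound 4 was reported as not active, with no number, so no step from compound 3 to compound 4 can be read. No measurement shown accounts for this result. Still open, as far as these compounds go, is whether phenylsulfonyl in place of benzyl gives the same outcome alongside the other substituents of compound 1 and compound 2.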